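Swapping the lactam for an aryl thioether: a cytotoxicity estimate

The source may report more compounds than this note shows. Statements on the series, on what has been measured and on what is new or still open speak of the compounds shown alone.

Compound 1 `Cc1cc(Sc2ccc(Cl)cc2)cn2c(CSCCc3ccccc3)cnc12`: 14 ug/mL
Compound 2 `Cc1cc(N2CCCC2=O)c2ncc(CSCCc3ccccc3)n2c1`: 25 ug/mL
Compound 3 `Cc1cc(Sc2ccc(Cl)cc2)c2ncc(CSCCc3ccccc3)n2c1`: not yet measured

In an ADME assay on HEL cells (Homo sapiens) for cytotoxicity, with a stated time of 3 days (on this read-out lower numbers stand for higher toxicity in this test and higher numbers for lower toxicity in this test), compound 2 gives 25 ug/mL and compound 1 gives 14 ug/mL. These two numbers lie within the usual scatter of each other, so they cannot be ranked. Compound 3 has (4-chlorophenyl)sulfanyl in place of 2-oxopyrrolidin-1-yl on an aromatic carbon of compound 2: (4-chlorophenyl)sulfanyl in place of 2-oxopyrrolidin-1-yl on an aromatic carbon. For the measured compounds named here, no measured pair shows this swap on its own. The closest guide is compound 1, which carries the same (4-chlorophenyl)sulfanyl group at a different place and gives 14 ug/mL. A move toward a lower number in this assay therefore seems possible, but nothing beyond the scatter is expected. The expected change is a 1.7-fold lower number from compound 2 to compound 3 (0.22 log units; within the scatter). The estimated value for compound 3 is 15 ug/mL, with an expected range from 6 ug/mL to 40 ug/mL.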

Compound 3, half-maximal cytotoxic concentration: 100 ug/mL
Compound 3: the middle estimate sits 6.7-fold (0.82 log units) below what was measured, and the stated range ends below it.
By their numbers in this assay, from the lowest: compounds 1 and 2 (each within the scatter of the next); then compound 3.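

In this assay, placing (4-chlorophenyl)sulfanyl in place of 2-oxopyrrolidin-1-yl on this aromatic carbon gives a 4.0-fold higher number from compound 2 to compound 3 (0.60 log units; beyond the scatter), so the change goes toward lower toxicity in this test. This shows that the number responds to what sits at this position, and that a six-membered aromatic ring of carbon only, carried through sulfur, does not raise toxicity here compared with the five-membered non-aromatic ring. Nothing measured here accounts for this shift.

For the compounds shown here, with only this one swap at the position, it remains open whether the shift follows the sulfur, the chlorine or the aromatic ring. A plain phenylsulfanyl group would test the chlorine, a 4-chlorophenoxy group would test the sulfur, and a simple amine such as piperidine would test the need for an aromatic ring.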